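Swapping the sulfur-bound heterocycle in a thiazolylidene hydrazide series

The compounds below may be only part of what the source reports. "The series", "measured", "known", "first", "only" and "open" are said of these compounds alone.

Measured so far in a functional assay on C6 cells (Rattus norvegicus) for cytotoxicity, read by MTT assay, with a stated time of 24 h, tested at 25 ug/mL; a higher number here means a weaker effect of the compound at the concentration tested, a lower number a stronger effect:
compound 1 `Cc1ccc(-c2cs/c(=N/NC(=O)CSc3nnnn3-c3ccccc3)n2-c2ccccc2)cc1` gives 38.8%
compound 2 `O=C(CSc1nnnn1-c1ccccc1)N/N=c1/scc(-c2ccc(F)cc2)n1-c1ccccc1` gives 49.3%
compound 3 `Cn1cnnc1SCC(=O)N/N=c1/scc(-c2ccccc2)n1-c1ccccc1` gives 77.3%

Compound 3 stands highest of the three numbers, that is, it shows the weakest effect at the tested concentration. Its nearest neighbour is compound 2, and compound 1 lies furthest away, both well beyond the scatter. Compound 4 `O=C(CSc1nnnn1-c1ccccc1)N/N=c1/scc(-c2ccccc2)n1-c1ccccc1` has not yet been measured. It differs from compound 3 in one place: 1-phenyl-1H-tetrazol-5-yl in place of 4-methyl-4H-1,2,4-triazol-3-yl on a sulfur.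

For the measured compounds named here, only one step has been measured, a number 10.5 percentage points higher from compound 1 to compound 2 (beyond the scatter), and it concerns a change on an aromatic carbon elsewhere in the molecule, so it does not bear directly on the change from compound 3 to compound 4. Going by the values given here, no measured step covers a change of the group on the sulfur. What the numbers do show is that both compounds carrying the 1-phenyl-1H-tetrazol-5-yl group, compound 1 and compound 2, sit well below compound 3.

A step downward in this assay is therefore expected, a number 31.3 percentage points lower from compound 3 to compound 4 (beyond the scatter), because compound 1 gives 38.8% and compound 2 gives 49.3%. For compound 4 the estimate is 46%, with a range from 32% to 64%.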

Compound 4, a percentage reported as activity, at one concentration (the size of the read-out at that concentration, not a potency): 42.5%
Compound 4: the middle estimate sits 3.5 percentage points above what was measured; measured number inside the range.
By their numbers in this assay, from the lowest: compounds 1, 4 and 2 (each within the scatter of the next, the first and the last beyond it); then compound 3.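

The exchange on the sulfur can now be read directly in this assay with the rest of the molecule unchanged: 1-phenyl-1H-tetrazol-5-yl in place of 4-methyl-4H-1,2,4-triazol-3-yl gives a number 34.8 percentage points lower from compound 3 to compound 4 (beyond the scatter), a large step that shows this position strongly affects the read-out in this small set. With the tetrazole group in place, the aromatic carbon appears less influential, as hydrogen in place of fluoro gives a number 6.8 percentage points lower from compound 2 to compound 4 (within the scatter) and hydrogen in place of methyl gives a number 3.7 percentage points higher from compound 1 to compound 4 (within the scatter). The exception is the exchange of methyl for fluoro, which gives a number 10.5 percentage points higher from compound 1 to compound 2 (beyond the scatter), although this remains much smaller than the change on the sulfur.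

The compounds shown do not separate the contribution of the five-membered ring from that of the added six-membered carbon ring, a question that a 1-methyl-1H-tetrazol-5-yl group on the sulfur could help to answer. No measurement shown explains the size of the step on the sulfur.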